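Cytotoxicity notes on a cinnamamide-quinazoline series

This account rests on a few compounds, and the source may have more. Where it says the series, first, only, none or still open, it means among the compounds named here.

The series shares a core carrying an anilino group with fluorine and chlorine and an acrylamide side chain that ends in a varied aryl group. In a functional assay on PC-3 cells (Homo sapiens) for cytotoxicity, read by MTT assay, with a stated time of 72 h (a higher number here means a weaker inhibitor, a lower number a stronger inhibitor), compound 1 `COc1ccc(/C=C/C(=O)Nc2cc3c(Nc4ccc(F)c(Cl)c4)ncnc3cc2OC)c(OC)c1` gives 38500 nM. Compound 2 `COc1cc(/C=C/C(=O)Nc2cc3c(Nc4ccc(F)c(Cl)c4)ncnc3cc2O[C@H]2CCOC2)cc(OC)c1OC` gives 20500 nM in this assay. Compound 3 `COc1cc2ncnc(Nc3ccc(F)c(Cl)c3)c2cc1NC(=O)/C=C/c1ccc(C#N)cc1` is reported in this assay as "not active" (no number reported), without a number. Compound 2 holds the lowest of the two numbers, but the gap to compound 1 falls within the scatter of repeated measurements, so no order between the two can be claimed. Compound 4 `O=C(/C=C/c1cc(Br)c(O)c(Br)c1)Nc1cc2c(Nc3ccc(F)c(Cl)c3)ncnc2cc1O[C@H]1CCOC1` is the next entry to be measured in this assay. It differs from compound 2 in one place: 3,5-dibromo-4-hydroxyphenyl in place of 3,4,5-trimethoxyphenyl on a double-bonded chain carbon bound to a double-bonded chain carbon. Among the compounds with values here, no step between measured compounds is available, so the size of this change cannot be read from the data. The number for compound 4 is expected to stay near that of compound 2, with a step of a 1.1-fold lower number from compound 2 to compound 4 (0.06 log units; within the scatter) that is not expected to exceed the scatter. Compound 4 is estimated at 18000 nM in this assay, within a range of 6000 nM to 60000 nM.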

Compound 4, half-maximal inhibitory concentration: 25500 nM
Compound 4: the middle estimate sits 1.4-fold (0.15 log units) below what was measured; the measured number falls inside the stated range.
By their numbers in this assay, from the lowest: compounds 2, 4 and 1 (each within the scatter of the next).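

Within the data shown here, replacing 3,4,5-trimethoxyphenyl with 3,5-dibromo-4-hydroxyphenyl on a double-bonded chain carbon bound to a double-bonded chain carbon gives the first readable step, in this assay: a 1.2-fold higher number from compound 2 to compound 4 (0.09 log units; within the scatter). At this position, the group can go from 12 heavy atoms to 9, and from 0 hydrogen-bond donors to 1, with two bromine atoms entering, and the step stays within the scatter. No measurement bears on why the number holds across this exchange.

Among these compounds, compound 3 carries no number, so no step involving it can be read. From the compounds shown here alone, whether an amine or a carboxylic acid on this aryl group, or a longer chain in its place, would move the number beyond the scatter remains open.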